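Chloro in Place of Trifluoromethyl on the Aryl Ring

The source may hold more compounds than are shown below. What is called first, only, known or untested is meant among the compounds shown, and "the series" means these compounds.

Measured so far in a functional assay on HUVEC cells (Homo sapiens) for antiproliferative activity; on this read-out higher numbers stand for weaker inhibition and lower numbers for stronger inhibition:
Compound 1 `Cc1nc2c([nH]1)C(=O)/C(=N/c1ccc(F)c(F)c1F)C(Cl)=C2O` gives 500 nM.
Compound 2 `Cc1nc2c([nH]1)C(=O)/C(=N/c1ccc(C(F)(F)F)cc1)C(Cl)=C2O` gives 600 nM.
Compound 3 `Cc1nc2c([nH]1)C(=O)/C(=N/c1cccc(Cl)c1)C(Cl)=C2O` gives 600 nM.

Compound 2 sits level with compound 3 on this assay, and compound 1 differs from compound 2 by a gap that lies within the usual scatter, so the three numbers cannot be ranked against one another. All three share a core and differ only in the groups carried on the aromatic ring.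

Compound 4 `Cc1nc2c([nH]1)C(=O)/C(=N/c1ccc(Cl)cc1)C(Cl)=C2O` has not been measured yet. Compared with compound 2 the change is chloro in place of trifluoromethyl on an aromatic carbon. The three measured compounds, each carrying a different substitution on that ring, give numbers that cannot be told apart, so no step beyond the scatter is expected here. The estimated step from compound 2 to compound 4 is no change at the digits printed from compound 2 to compound 4 (within the scatter). Compound 4 is expected to give about 600 nM, with a likely range from 250 nM to 1500 nM.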

Compound 4, half-maximal inhibitory concentration: 800 nM
Compound 4: middle estimate off by 1.3-fold (0.12 log units), on the low side, and the stated range covers the measured number.
By their numbers in this assay, from the lowest: compounds 1, 2, 3 and 4 (each within the scatter of the next).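

Swapping trifluoromethyl for chloro on this aromatic carbon gives a 1.3-fold higher number from compound 2 to compound 4 (0.12 log units; within the scatter) in this assay, so this replacement has no readable effect. Shifting the chlorine, with 4-chlorophenyl in place of 3-chlorophenyl, gives a 1.3-fold higher number from compound 3 to compound 4 (0.12 log units; within the scatter), so this change of place cannot be read either. No measurement shown offers an explanation for these results.

All the ring substituents shown are fluoro, chloro or trifluoromethyl. As far as these compounds go, whether an amine or a carboxylic acid on this ring would give a step beyond the scatter remains open.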